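The compounds below may be only part of what the source reports. "The series", "measured", "known", "first", "only" and "open" are said of these compounds alone.

Series notes, shared core. Compound 1 `CCOC(=O)c1sc2ccc(NCc3nc[nH]c3C)cc2c1NC(=O)c1ccccc1` gives 23300 nM in a functional assay on HeLa cells (Homo sapiens) for antiproliferative activity, read by MTT assay, with a stated time of 48 h; a higher number here means a weaker inhibitor of growth, a lower number a stronger inhibitor of growth. Compound 2 `CCOC(=O)c1sc2ccc(NCc3nc[nH]c3C)cc2c1NC(=O)c1ccc(C)cc1` gives 11400 nM in this assay, the change being a 2.0-fold lower number from compound 1 to compound 2 (0.31 log units; beyond the scatter). Compound 3 `CCOC(=O)c1sc2ccc(NCc3nc[nH]c3C)cc2c1NC(=O)c1cc(OC)c(OC)c(OC)c1` gives 2230 nM in this assay and stands lowest of the three numbers; its nearest neighbour is compound 2, with a 5.1-fold lower number from compound 2 to compound 3 (0.71 log units; beyond the scatter), and its furthest is compound 1, with a 10-fold lower number from compound 1 to compound 3 (1.02 log units; beyond the scatter).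

Compound 4 `CCOC(=O)c1sc2ccc(NCc3nc[nH]c3C)cc2c1NC(=O)c1ccc(F)c(Cl)c1` is not yet measured. The change from compound 3 is 3-chloro-4-fluorophenyl in place of 3,4,5-trimethoxyphenyl on a carbonyl carbon. Within the data shown here, the steps from compound 1 and compound 2 into compound 3 are the only information on the aryl group at this carbonyl, and both show the 3,4,5-trimethoxyphenyl giving the lowest number; the halogenated ring of compound 4 has no measured counterpart here, and the phenyl and 4-methylphenyl are the closest examples of a ring without that substitution. The expectation for compound 4 in this assay is therefore a rise in the number, with the step of a 3.1-fold higher number from compound 3 to compound 4 (0.50 log units; beyond the scatter) expected to be modest and to land compound 4 between the values of compound 2 and compound 3. The estimate for compound 4 is 7000 nM, with a range from 2500 nM to 20000 nM.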

Compound 4, concentration for 50% growth inhibition: 2910 nM
Estimate against measurement, compound 4: 2.4-fold (0.38 log units) above; low and high end bracket the measured number.
By their numbers in this assay, from the lowest: compounds 3 and 4 (each within the scatter of the next); then compound 2; then compound 1.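

In this assay, among these compounds, the 3,4,5-trimethoxyphenyl is no longer the only aryl group on this carbonyl carbon to reach the low end of the series: the 3-chloro-4-fluorophenyl ring, which has no methoxy groups, cannot be told apart from it (a 1.3-fold higher number from compound 3 to compound 4 (0.12 log units; within the scatter)), so these methoxy groups are not required for numbers at this level. The halogenated ring also stands clear of the two simpler rings, with a 3.9-fold lower number from compound 2 to compound 4 (0.59 log units; beyond the scatter) and an 8.0-fold lower number from compound 1 to compound 4 (0.90 log units; beyond the scatter), so two differently substituted rings now share the advantage over phenyl and 4-methylphenyl, and the series no longer points to a single substitution pattern. Nothing shown accounts for why such different rings give matching numbers.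

Still open, from the compounds shown here alone, is whether one halogen can do the work of both, as 4-fluorophenyl and 3-chlorophenyl would show, and how a ring bearing a carboxylic acid or a dimethylamino group would behave at this carbonyl carbon. Going by these compounds, all of the aryl comparisons also rest on a single cell line and on one fixed remainder of the molecule, so it is unknown whether the match between these two rings holds elsewhere.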